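Swapping the aminoheteroaryl ring on the shared aryl amine

This account rests on a few compounds, and the source may have more. Where it says the series, first, only, none or still open, it means among the compounds named here.

Measured compounds:
- compound 1, `Nc1nccc(Nc2ccc(Oc3ccc(Cl)cc3)cc2)n1`: 206 mL.min-1.g-1
- compound 2, `Nc1cccc(Nc2ccc(Oc3ccc(Cl)cc3)cc2)n1`: 100 mL.min-1.g-1

In an in vitro ADME assay on microsomes from liver (Homo sapiens) for metabolic stability (on this read-out lower numbers stand for slow clearance and higher numbers for fast clearance), compound 1 gives 206 mL.min-1.g-1, the highest of the two numbers measured; its nearest neighbour is compound 2 with 100 mL.min-1.g-1. Among the measured compounds shown here, the only step recorded is a 2.1-fold lower number from compound 1 to compound 2 (0.31 log units; beyond the scatter), where the change is the swap of the ring that carries the amino group, at the same place as the change now considered.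

Compound 3, `Nc1nsc(Nc2ccc(Oc3ccc(Cl)cc3)cc2)n1`, has not yet been measured in this assay. It differs from compound 1 as follows: 3-amino-1,2,4-thiadiazol-5-yl in place of 2-aminopyrimidin-4-yl on a nitrogen on an aromatic ring. For the measured compounds named here, the one step at this position, from compound 1 to compound 2, was modest and beyond the scatter, so a small lowering or a step within the scatter is expected here; no larger movement is suggested by the two numbers available. Compound 3 is therefore estimated at 150 mL.min-1.g-1, within 60 mL.min-1.g-1 to 350 mL.min-1.g-1, which would mean an expected step of a 1.4-fold lower number from compound 1 to compound 3 (0.14 log units; within the scatter).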

Compound 3, intrinsic clearance in microsomes: < 14 mL.min-1.g-1
Compound 3 ended at the assay's limit (the forecaster's own chance of this, stated with the estimate: 5%); at least 10-fold (1.02 log units) between middle value and limit.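

On this position, on a nitrogen on an aromatic ring, the ring carrying the amino group matters far more in this assay than the earlier pair showed: the 3-amino-1,2,4-thiadiazol-5-yl group gives an at least 14-fold lower number from compound 1 to compound 3 (1.16 log units; beyond the scatter), and an at least 7.1-fold lower number from compound 2 to compound 3 (0.85 log units; beyond the scatter). Compound 3 stands at a limit of the assay and not at a number, so both steps give only a minimum size: the limit of < 14 mL.min-1.g-1 in this assay, at which 1 of the 3 values shown sits. With a single five-membered ring in the set, the step cannot be assigned to ring size or to the sulfur that enters with it.

The compounds shown leave that question open; a 3-amino-1,2,4-oxadiazol-5-yl group, with oxygen in place of sulfur, would bear on it. They also leave open whether the amine on the thiadiazole matters, which a methyl group in its place would test.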